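This account rests on a few compounds, and the source may have more. Where it says the series, first, only, none or still open, it means among the compounds named here.

In a functional assay on M21 cells (Homo sapiens) for antiproliferative activity, read by sulforhodamine B assay, with a stated time of 48 h (on this read-out higher numbers stand for weaker inhibition and lower numbers for stronger inhibition), compound 1 `CCc1ccccc1NS(=O)(=O)c1ccc(N2CCNC2=O)cc1` gives 180 nM and compound 2 `O=C1NCCN1c1ccc(S(=O)(=O)Nc2ccc(F)cc2)cc1` gives 230 nM in this series. Their gap is a 1.3-fold higher number from compound 1 to compound 2 (0.11 log units; within the scatter) and so sets neither compound ahead. Compound 3 `CCc1ccc(NS(=O)(=O)c2ccc(N3CCNC3=O)cc2)cc1` gives 480 nM and is the weakest of the three, with a 2.7-fold higher number from compound 1 to compound 3 (0.43 log units; beyond the scatter) and a 2.1-fold higher number from compound 2 to compound 3 (0.32 log units; beyond the scatter) as its steps from the others.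

Compound 4 `O=C1NCCN1c1ccc(S(=O)(=O)Nc2ccc(F)c(F)c2)cc1` differs from compound 3 in one place, with 3,4-difluorophenyl in place of 4-ethylphenyl on a sulfonamide nitrogen is the full count of that change. Among the measured compounds shown here, the measured step that bears most directly on it is the one linking compound 2 and compound 3, a 2.1-fold higher number from compound 2 to compound 3 (0.32 log units; beyond the scatter) as an exchange of fluoro for ethyl. Read backwards, it points to a modest fall in the number on leaving the ethyl group. For the measured compounds named here, no measured compound shows what a second fluoro does, so compound 2 is only an approximate guide. A modest drop in this assay is therefore expected, of about the size of that step and close to the edge of the scatter. The estimated step is a 1.8-fold lower number from compound 3 to compound 4 (0.27 log units; within the scatter) in this case. For compound 4 the expected value is 260 nM within an estimated range from 110 nM to 600 nM in this read-out.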

Compound 4, half-maximal inhibitory concentration: 220 nM
Estimate against measurement, compound 4: 1.2-fold (0.07 log units) above; the range from low to high includes it.
By their numbers in this assay, from the lowest: compounds 1, 4 and 2 (each within the scatter of the next); then compound 3.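

In this assay, 3,4-difluorophenyl in place of 4-ethylphenyl on a sulfonamide nitrogen gives a 2.2-fold lower number from compound 3 to compound 4 (0.34 log units; beyond the scatter), so the step away from the ethyl group seen earlier with a single fluoro also holds with two fluoro groups on the ring. Fluoro in place of hydrogen on an aromatic carbon gives a 1.0-fold lower number from compound 2 to compound 4 (0.02 log units; within the scatter), and 3,4-difluorophenyl in place of 2-ethylphenyl gives a 1.2-fold higher number from compound 1 to compound 4 (0.09 log units; within the scatter), so the second fluoro does not set compound 4 apart from compound 2 or compound 1, and compound 3 alone stands beyond the scatter from the other three. Nothing measured here offers a reason for any of these steps.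

The aryl groups shown carry only ethyl and fluoro, which leaves open how a chloro group, a methoxy group, an amine or a carboxylic acid on that ring would read in this assay. All four compounds also keep the shared core unchanged, so they say nothing about how a methyl group on the amide hydrogen's nitrogen or a longer chain on the core would affect the number.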